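The source may report more compounds than this note shows. Statements on the series, on what has been measured and on what is new or still open speak of the compounds shown alone.

Compound 1 `Cc1ccccc1C(=O)Nc1cccc(-c2oc3cc(-c4ccc(F)cc4)ccc3c(=O)c2O)c1`: 24800 nM
Compound 2 `O=C(Nc1cccc(-c2oc3cc(-c4ccc(F)cc4)ccc3c(=O)c2O)c1)c1cccc(F)c1`: 15800 nM
Compound 3 `Cc1cc(C(=O)Nc2cccc(-c3oc4cc(-c5ccc(F)cc5)ccc4c(=O)c3O)c2)ccc1F`: 12100 nM

These three compounds share one core and differ only in the aromatic group attached to the carbonyl carbon of the amide. In a functional assay on GTL 16 cells for antiproliferative activity against GTL 16 cell line (Homo sapiens), read by CCK-8 assay, with a stated time of 72 h (on this read-out higher numbers stand for weaker inhibition and lower numbers for stronger inhibition), compound 3 gives 12100 nM, the lowest of the three numbers, but one of its gaps is a 1.3-fold lower number from compound 2 to compound 3 (0.12 log units; within the scatter), so those two cannot be ranked against each other; only the other gap, a 2.0-fold lower number from compound 1 to compound 3 (0.31 log units; beyond the scatter), stands beyond the scatter, and even that is modest.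

Compound 4 `O=C(Nc1cccc(-c2oc3cc(-c4ccc(F)cc4)ccc3c(=O)c2O)c1)c1ccc([N+](=O)[O-])cc1` carries the next change at the same place: 4-nitrophenyl in place of 4-fluoro-3-methylphenyl on a carbonyl carbon. All three measured steps swap one aromatic group for another on this carbonyl carbon, and all were small: a 1.6-fold lower number from compound 1 to compound 2 (0.20 log units; within the scatter), a 2.0-fold lower number from compound 1 to compound 3 (0.31 log units; beyond the scatter) and a 1.3-fold lower number from compound 2 to compound 3 (0.12 log units; within the scatter). None of them introduced a nitro group, so the data give no direct guide for that group, and the expectation rests on the observation that exchanging the aryl group here has so far moved this assay only a little. The step from compound 3 to compound 4 is therefore expected to be a 1.2-fold higher number from compound 3 to compound 4 (0.06 log units; within the scatter), most likely within the scatter. Compound 4 is estimated to give 14000 nM in this assay, with a range from 6000 nM to 32000 nM.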

Compound 4, half-maximal inhibitory concentration: 18200 nM
Estimate against measurement, compound 4: 1.3-fold (0.11 log units) below; low and high end bracket the measured number.
By their numbers in this assay, from the lowest: compounds 3, 2, 4 and 1 (each within the scatter of the next, the first and the last beyond it).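

In this assay, the 4-nitrophenyl group on this carbonyl carbon cannot be told apart from any of the three earlier aromatic groups: a 1.5-fold higher number from compound 3 to compound 4 (0.18 log units; within the scatter), a 1.2-fold higher number from compound 2 to compound 4 (0.06 log units; within the scatter) and a 1.4-fold lower number from compound 1 to compound 4 (0.13 log units; within the scatter) all lie within the scatter. Going by these compounds alone, it is the first group at this place to bring in nitrogen and oxygen atoms, and it counts two hydrogen-bond acceptors where 4-fluoro-3-methylphenyl counts none, yet this difference in make-up gives no step beyond the scatter, and the only gap of that kind among the four compounds remains the earlier one between compound 1 and compound 3. No measurement at hand offers an explanation for this result.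

From the compounds shown here alone, all four compounds carry an uncharged six-membered aromatic ring of carbon on this carbonyl carbon, so it remains open whether an amine, a carboxylic acid or a longer alkyl chain in its place would give a step clearly beyond the scatter. Going by these compounds, it also remains open whether a change elsewhere on the shared core would move the number further than these exchanges have.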